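The source may hold more compounds than are shown below. What is called first, only, known or untested is meant among the compounds shown, and "the series" means these compounds.

Measured compounds:
- compound 1, `CCOC(=O)CN(c1nc(Cl)nc2c1ncn2C1CCCCO1)C1CC1`: 13%
- compound 2, `C[C@H](NC(=O)CN(c1nc(Cl)nc2c1ncn2C1CCCCO1)C1CC1)C(=O)OCc1ccccc1`: 32.1%
- compound 3, `NC(=O)C[C@H](NC(=O)CN(c1nc(Cl)nc2c1ncn2C1CCCCO1)C1CC1)C(=O)OCc1ccccc1`: 35%

In a functional assay on the whole organism with Mus musculus as the target, with a stated time of 90 min, at a dose of 25 umol/kg by the oral route (on this read-out higher numbers stand for a stronger effect at the one dose given and lower numbers for a weaker effect), compound 3 gives 35%, the highest of the three numbers recorded. Compound 2, at 32.1%, sits within the scatter of that value, so the two cannot be told apart; compound 1, at 13%, lies beyond the scatter below both of them, and since compound 1 differs from the other two in more than one place, only its value can be set beside theirs.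

Compound 4, `O=C(CN(c1nc(Cl)nc2c1ncn2C1CCCCO1)C1CC1)N[C@@H](CCC(=O)OCc1ccccc1)C(=O)OCc1ccccc1`, has not yet been measured in this assay. It differs from compound 3 by (benzyloxycarbonyl)methyl in place of carbamoyl on a saturated chain carbon, two bonds along the chain from an amide-type nitrogen and a carbonyl carbon.

For the measured compounds named here, only one measured step touches the same position: a number 2.9 percentage points higher from compound 2 to compound 3 (within the scatter), which put the carbamoyl in place of hydrogen and stayed within the scatter. Going by the values given here, no measured step shows a (benzyloxycarbonyl)methyl entering anywhere, so the data give no direction for the change from compound 3 to compound 4. On that basis the expected step is a number 2 percentage points lower from compound 3 to compound 4 (within the scatter), none beyond the scatter. Compound 4 is therefore estimated at 33% in this assay, with a likely range from 18% to 48%.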

Compound 4, a percentage reported as activity, at one dose (the size of the read-out at that dose, not a potency): 25.2%
For compound 4 the middle estimate is 7.8 percentage points above the measured one; low and high end bracket the measured number.
By their numbers in this assay, from the lowest: compound 1; then compounds 4, 2 and 3 (each within the scatter of the next).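

In this assay, the saturated chain carbon, two bonds along the chain from an amide-type nitrogen and a carbonyl carbon, now carries a far larger group: (benzyloxycarbonyl)methyl, with 11 heavy atoms and a six-membered aromatic ring, replaces carbamoyl, with 3 heavy atoms and no ring, and the single hydrogen-bond donor of carbamoyl goes with it, yet the change gives a number 9.8 percentage points lower from compound 3 to compound 4 (within the scatter). Measured against hydrogen at the same place, the group gives a number 6.9 percentage points lower from compound 2 to compound 4 (within the scatter), so hydrogen, carbamoyl and (benzyloxycarbonyl)methyl cannot be told apart at this carbon on this read-out. No independent measurement is available to explain this result.

The compounds shown leave open whether a free carboxylic acid, an amine or a longer chain at this carbon would move the number beyond the scatter, since all three groups tested so far stay within it. Compound 1 differs from the others in more than one place, so its value cannot be tied to any single change.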